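Chloro removal on the shared core: expectation for compound 4

The source may hold more compounds than are shown below. What is called first, only, known or untested is meant among the compounds shown, and "the series" means these compounds.

Compound 2 `FC(F)(F)Oc1ccc(Oc2ccnc(N3CCC(NC(=S)Nc4cccnc4)CC3)c2Cl)cc1` gives 25 nM in an assay on membranes from brain for binding affinity to Lysophosphatidylserine lipase ABHD12 (Mus musculus), read by fluorescence, with a stated time of 20 min (on this read-out lower numbers stand for stronger inhibition and higher numbers for weaker inhibition), and holds the lowest number of the three measured compounds. Compound 3 `FC(F)(F)Oc1cccc(Oc2ccnc(N3CCC(NC(=S)Nc4cccnc4)CC3)c2Cl)c1` gives 89 nM, and compound 1 `FC(F)(F)Oc1ccccc1Oc1ccnc(N2CCC(NC(=S)Nc3cccnc3)CC2)c1Cl` gives 96 nM. The step of a 3.6-fold higher number from compound 2 to compound 3 (0.55 log units; beyond the scatter) and the step of a 3.8-fold lower number from compound 1 to compound 2 (0.58 log units; beyond the scatter) both lie beyond the scatter, while a 1.1-fold lower number from compound 1 to compound 3 (0.03 log units; within the scatter) does not. All three concern only the position of the trifluoromethoxy group and leave the rest of the shared core untouched.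

Compound 4 `FC(F)(F)Oc1ccc(Oc2ccnc(N3CCC(NC(=S)Nc4cccnc4)CC3)c2)cc1` differs from compound 2 at another place: hydrogen in place of chloro on an aromatic carbon, on an aromatic carbon of a six-membered aromatic ring with 1 nitrogen, ortho to two large groups, two atoms from the ring nitrogen. Among the measured compounds shown here, no measured step bears on this change. Every measured step varies the trifluoromethoxy position alone, so the series shows nothing about what the chloro at this carbon contributes. The expectation rests on compound 2 alone and carries a wide range.

Compound 4 is expected to give 60 nM in this assay, with a range from 15 nM to 250 nM. The estimated step is a 2.4-fold higher number from compound 2 to compound 4 (0.38 log units; beyond the scatter), set on the weaker side with wide margins to reflect the absence of any measured step on this change.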

Compound 4, half-maximal inhibitory concentration: 410 nM
Estimate against measurement, compound 4: 6.8-fold (0.83 log units) below; measured number above the stated range.
By their numbers in this assay, from the lowest: compound 2; then compounds 3 and 1 (each within the scatter of the next); then compound 4.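

In this assay the chloro on this aromatic carbon, ortho to two large groups and two atoms from the ring nitrogen, proves to matter strongly: hydrogen in its place gives a 16-fold higher number from compound 2 to compound 4 (1.21 log units; beyond the scatter), a step larger than any among the three trifluoromethoxy positions, and it leaves compound 4 with the highest number of the four compounds. The earlier compounds shown here showed sensitivity only on the aryl group on the oxygen, whereas this result adds a second place on the shared core where the number responds, here with 4-(trifluoromethoxy)phenyl held constant. No supporting data accompany this result, so the reason for the loss stays unexplained.

Still open, going by these compounds, is whether the requirement at this carbon is specific to chloro or would also be met by fluoro, bromo, methyl or a nitrile, any of which would separate a need for chloro itself from a need for some group other than hydrogen. Also open, on these data alone, is whether the chloro step has a similar size with 2-(trifluoromethoxy)phenyl or 3-(trifluoromethoxy)phenyl on the oxygen.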